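The compounds below may be only part of what the source reports. "The series", "measured", "known", "first", "only" and "open" are said of these compounds alone.

Compound 1 `Cc1cccnc1N(C(=O)N1CCC(c2ccccc2)CC1)[C@@H]1CCCNC1` sits at the floor of an ADME assay on microsomes from liver (Homo sapiens) for metabolic stability; on this read-out lower numbers stand for slow clearance and higher numbers for fast clearance: its result there is a limit of the assay, < 8 mL.min-1.g-1, not a number. Compound 2 `Cn1ccc2ccnc(N(C(=O)N3CCC(c4ccccc4)CC3)[C@@H]3CCCNC3)c21` differs from compound 1 on the amide-type nitrogen, and in this assay compound 2 gives 11.8 mL.min-1.g-1; that step was an at least 1.4-fold higher number from compound 1 to compound 2 (0.16 log units; that floor lies within the scatter). Compound 3 `Cc1cccnc1N(C(=O)N1CCC(c2cnn3cccnc23)CC1)[C@@H]1CCCNC1` alters compound 1 at a different place: a group of 9 heavy atoms (6 carbon, 3 nitrogen; one five-membered aromatic ring with 2 hetero atoms, one six-membered aromatic ring with 2 hetero atoms) in place of a group of 6 heavy atoms (6 carbon; one six-membered aromatic ring of carbon only), on a saturated ring carbon. Among the measured compounds shown here, no measured step touches this saturated ring carbon, so nothing anchors the size of this step. Compound 3 is therefore expected near the floor, at 6 mL.min-1.g-1, with a range from 3 mL.min-1.g-1 to 14 mL.min-1.g-1. That corresponds to an expected step that the limit leaves unreadable from compound 1 to compound 3.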

Compound 3, intrinsic clearance in microsomes: < 8 mL.min-1.g-1
Compound 3 was reported as a limit; the forecaster's own chance of this, stated with the estimate: 55%; the middle value does not contradict the limit.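

No step can be read between compound 1 and compound 3, because each result is a limit and not a number: the limit of < 8 mL.min-1.g-1 in this assay, at which 2 of the 3 values shown sit.

On these data alone, the true clearance of each compound, and so the effect of replacing the phenyl group, stays open.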